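The source may hold more compounds than are shown below. What is called first, only, known or untested is meant among the compounds shown, and "the series" means these compounds.

Measured so far in an assay on isolated protein for displacement of a labelled ligand from Apoptosis regulator Bcl-2 (Homo sapiens), with a stated time of 15 min; on this read-out higher numbers stand for weaker inhibition and lower numbers for stronger inhibition:
compound 1 `CC1(C)CCC(CN2CCN(c3ccc(C(=O)NS(=O)(=O)c4ccc(NCC5CCOCC5)c([N+](=O)[O-])c4)c(Oc4cnc5[nH]ccc5c4)c3)CC2)=C(c2ccc(C(F)(F)F)cc2)C1`: 1.5 nM
compound 2 `CN1CCC(CNc2ccc(S(=O)(=O)NC(=O)c3ccc(N4CCN(CC5=C(c6ccc(C(F)(F)F)cc6)CC(C)(C)CC5)CC4)cc3Oc3cnc4[nH]ccc4c3)cc2[N+](=O)[O-])C1`: 2.4 nM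

Compound 1 has the lowest of these two numbers; the nearest is compound 2, with a step of a 1.6-fold higher number from compound 1 to compound 2 (0.20 log units; within the scatter). Compound 3 `CCN1CCC(COc2ccc(S(=O)(=O)NC(=O)c3ccc(N4CCN(CC5=C(c6ccc(C(F)(F)F)cc6)CC(C)(C)CC5)CC4)cc3Oc3cnc4[nH]ccc4c3)cc2[N+](=O)[O-])CC1` differs from compound 1 in one place: (1-ethylpiperidin-4-yl)methoxy in place of ((oxan-4-yl)methyl)amino on an aromatic carbon. Going by the values given here, the single measured step, from compound 1 to compound 2, altered only the ring of the ((oxan-4-yl)methyl)amino group and stayed within the scatter, while here the whole group is replaced, so the data bear on it only partly. The expected step is a 2.0-fold higher number from compound 1 to compound 3 (0.30 log units; within the scatter), not beyond the scatter. Compound 3 is therefore estimated at 3 nM, with a range from 1 nM to 10 nM.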

Compound 3, half-maximal inhibitory concentration: 0.5 nM
Estimate against measurement, compound 3: 6.0-fold (0.78 log units) above; the whole stated range lies above it.
By their numbers in this assay, from the lowest: compound 3; then compounds 1 and 2 (each within the scatter of the next).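

In this assay the earlier swap of one ring for another stayed within the scatter, but replacing the whole group on this aromatic carbon goes beyond it (a 3.0-fold lower number from compound 1 to compound 3 (0.48 log units; beyond the scatter); a 4.8-fold lower number from compound 2 to compound 3 (0.68 log units; beyond the scatter)). This position, ortho to a nitro group, therefore does respond to change, and compound 3 has the lowest number of the three. No measurement shown gives a reason for these steps.

From the compounds shown here alone, the linking atom and the ring changed together, so their shares stay unknown. A (oxan-4-yl)methoxy group, keeping the ring but linking through oxygen, would separate them.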